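A few compounds are considered here, and "the series" means these few. Any claim that something is new, unique, unknown or untested is made for them only; others in the source may bear on it.

Measured so far:
Compound 1 `Nc1nc(-c2ccccn2)nn1-c1ncnc2ccccc12`: in an assay on MCF7 cells for inhibition of Serine-protein kinase ATM (Homo sapiens), read by immunofluorescence, with a stated time of 1 h (on this read-out higher numbers stand for weaker inhibition and lower numbers for stronger inhibition), compound 1 gives > 40000 nM, a limit of the assay.
Compound 2 `COc1cc2ncnc(-n3nc(-c4ccccn4)nc3N)c2cc1[N+](=O)[O-]`: in this assay compound 2 gives 31100 nM.
Compound 3 `Nc1nc(-c2ccccn2)nn1-c1ncnc2cc(N3CCNCC3)c([N+](=O)[O-])cc12`: in this assay compound 3 gives > 40000 nM, a limit of the assay.

For the measured compounds named here, compound 2 thus stands as the only number in the set, the other two entries being limits (the limit of > 40000 nM in this assay, at which 2 of the 3 values shown sit). Compound 4 `COc1cc2ncnc(-n3nc(-c4ccccn4)nc3N)c2cc1OCc1ccccc1` differs from compound 2 by benzyloxy in place of nitro on an aromatic carbon. Going by the values given here, the one measured step, an at least 1.2-fold higher number from compound 2 to compound 3 (0.10 log units; that floor lies within the scatter), exchanges a different group and ends at a limit, so it gives no guide to the exchange of the nitro group; no measured step bears on it directly. No direction can be expected beyond the scatter, and the step of a 1.1-fold lower number from compound 2 to compound 4 (0.05 log units; within the scatter) is therefore expected to be small. For compound 4 the estimate is 28000 nM, between 5000 nM and 120000 nM.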

Compound 4, half-maximal inhibitory concentration: 8600 nM
Beside the measured number, compound 4's estimate is 3.3-fold (0.51 log units) above it, and the stated range covers the measured number.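

In this assay, for the compounds shown here, the ring carbon ortho to a methoxy group gives the first step between two actual numbers: a 3.6-fold lower number from compound 2 to compound 4 (0.56 log units; beyond the scatter). The earlier step changed the methoxy position instead and ended at a limit. Here, benzyloxy, far larger than nitro, is accompanied by a lower number, so this position accepts an added aromatic ring without loss.

Going by these compounds, whether the ring or the ether oxygen carries the step stays open, and an amine or a plain ethoxy chain here would separate them. Steps ending at a limit give no size: the limit of > 40000 nM in this assay, at which 2 of the 4 values shown sit.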